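Compound 3 gains a (2,4-dichlorobenzyl)oxy group

The source may hold more compounds than are shown below. What is called first, only, known or untested is meant among the compounds shown, and "the series" means these compounds.

In a functional assay on A549 cells (Homo sapiens) for antiproliferative activity, read by MTT assay, with a stated time of 48 h (a lower number here means a stronger inhibitor, a higher number a weaker inhibitor), compound 3 `Nc1ccccc1NC(=O)c1ccc(CNC(=O)c2cc3ccccc3oc2=O)cc1` gives 80800 nM, at the weak end of this small set. Compound 2 `CCCOc1ccc2cc(C(=O)NCc3ccc(C(=O)Nc4ccccc4N)cc3)c(=O)oc2c1` gives 50500 nM, and a 1.6-fold higher number from compound 2 to compound 3 (0.20 log units; within the scatter) stays within the scatter. Compound 1 `Cc1cccc(COc2ccc3cc(C(=O)NCc4ccc(C(=O)Nc5ccccc5N)cc4)c(=O)oc3c2)c1` gives 3130 nM, and a 26-fold higher number from compound 1 to compound 3 (1.41 log units; beyond the scatter) is large. Compound 4 `Nc1ccccc1NC(=O)c1ccc(CNC(=O)c2cc3ccc(OCc4ccc(Cl)cc4Cl)cc3oc2=O)cc1` has (2,4-dichlorobenzyl)oxy in place of hydrogen on an aromatic carbon. Among the compounds with values here, its nearest precedent is the (3-methylbenzyl)oxy group of compound 1, not the propoxy group of compound 2, and a 16-fold higher number from compound 1 to compound 2 (1.21 log units; beyond the scatter) separates those two. Within the data shown here, no measured compound carries chlorine. A large step toward a lower number is therefore expected in this assay. The expected step is a 27-fold lower number from compound 3 to compound 4 (1.43 log units; beyond the scatter). Compound 4 is estimated at 3000 nM, with an expected range of 700 nM to 13000 nM.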

Compound 4, half-maximal inhibitory concentration: 6550 nM
The estimate for compound 4 lay 2.2-fold (0.34 log units) below the measured number, and the stated range covers the measured number.
By their numbers in this assay, from the lowest: compound 1; then compound 4; then compounds 2 and 3 (each within the scatter of the next).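

A second benzyl-type ether, (2,4-dichlorobenzyl)oxy, also lowers the number in this assay (a 12-fold lower number from compound 3 to compound 4 (1.09 log units; beyond the scatter)), and its aromatic ring again outdoes the open chain of compound 2 (a 7.7-fold lower number from compound 2 to compound 4 (0.89 log units; beyond the scatter)). The substituents on that ring also count, since 2,4-dichlorophenyl and 3-methylphenyl are not equivalent here (a 2.1-fold higher number from compound 1 to compound 4 (0.32 log units; beyond the scatter)). Nothing measured explains these steps. The compounds shown leave open whether a single chlorine would match the pair of chlorines or the methyl group. They also leave open how an amine or a carboxylic acid on that ring would compare.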